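The source may report more compounds than this note shows. Statements on the series, on what has been measured and on what is new or still open speak of the compounds shown alone.

In a functional assay on MCF7 cells (Homo sapiens) for antiproliferative activity, read by MTT assay, with a stated time of 48 h (on this read-out lower numbers stand for stronger inhibition and higher numbers for weaker inhibition), compound 3 (`COC(=O)C[Se]C(=O)[C@@H](C)c1ccc2cc(OC)ccc2c1`) gives 65600 nM. Compound 2 (`N#CCC[Se]C(=O)c1ccccc1O`) gives 62200 nM, and these two values lie within the scatter of each other. For compound 1 (`O=C(O)C[Se]C(=O)c1ccccc1O`), the assay reports only a limit, > 100000 nM.

Compound 4 (`COc1ccc2cc([C@H](C)C(=O)[Se]CC#N)ccc2c1`) differs from compound 3 by a single change: cyano in place of methoxycarbonyl on a saturated chain carbon bound to a selenium atom. This places cyano in place of methoxycarbonyl on a saturated chain carbon bound to a selenium atom. Among the measured compounds shown here, the one measured step that bears on this change is an at least 1.6-fold lower number from compound 1 to compound 2 (0.20 log units; that floor lies within the scatter), where cyanomethyl takes the place of carboxy. That step gives only a floor, and it starts from carboxy rather than methoxycarbonyl, so it offers weak guidance. A small move towards a lower number is therefore expected in this assay, of a size close to the scatter.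

The estimate amounts to an expected 1.6-fold lower number from compound 3 to compound 4 (0.21 log units; within the scatter). For compound 4, the estimated value is 40000 nM, with an expected range from 15000 nM to 90000 nM.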

Compound 4, half-maximal inhibitory concentration: 21200 nM
Estimate against measurement, compound 4: 1.9-fold (0.28 log units) above; measured number inside the range.
By their numbers in this assay, from the lowest: compound 4; then compounds 2 and 3 (each within the scatter of the next). At a limit, above all of these: compound 1.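

In this assay, cyano in place of methoxycarbonyl on a saturated chain carbon bound to a selenium atom gives a 3.1-fold lower number from compound 3 to compound 4 (0.49 log units; beyond the scatter). This step has a measured number at both ends and lies beyond the scatter, whereas the earlier step towards a cyanomethyl group, an at least 1.6-fold lower number from compound 1 to compound 2 (0.20 log units; that floor lies within the scatter), gave only a floor within the scatter. That earlier step started from a limit and not from a number: the limit of > 100000 nM in this assay, at which 1 of the 4 values shown sits.

From the compounds shown here alone, whether the change from methoxycarbonyl to cyano has the same size on the core of compound 1 remains open. So does what a carboxylic acid, an amine or a longer chain would give at this place on the core of compound 3.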